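A few compounds are considered here, and "the series" means these few. Any claim that something is new, unique, unknown or untested is made for them only; others in the source may bear on it.

Compound 1 `CCc1ccc(-c2nc(N)c3cc(CN4[C@H](C)CCC[C@@H]4C)sc3n2)o1` is the stronger of the two measured compounds in an assay on CHO-K1 cells for antagonist activity at adenosine receptor A1 (Homo sapiens), read by a beta-galactosidase reporter, with stated times of 15 min and 6 h; a higher number here means a weaker inhibitor, a lower number a stronger inhibitor. In this assay compound 1 gives 190 nM, the lowest number of the pair. Among the compounds with values here, compound 2 `Nc1nc(-c2ccc(Br)o2)nc2sc(CN3CCCC3)cc12` differs from it in more than one place, so no single step connects them; in this assay compound 2 gives 710 nM, and the two numbers lie apart by more than the usual scatter.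

Compound 3 `Cc1csc(-c2nc(N)c3cc(CN4[C@H](C)CCC[C@@H]4C)sc3n2)n1` differs from compound 1 in one place only, by 4-methyl-1,3-thiazol-2-yl in place of 5-ethylfuran-2-yl on an aromatic carbon of the shared core. Within the data shown here, no measured pair shows the effect of this exchange, so its size cannot be read from the data. The outcome for compound 3 is expected to be a modest move toward a weaker inhibitor, a step of a 2.1-fold higher number from compound 1 to compound 3 (0.32 log units; beyond the scatter), with a real chance that it stays within the scatter of compound 1. Compound 3 is therefore estimated at 400 nM in this assay, within a range from 120 nM to 1300 nM.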

Compound 3, inhibition constant: 300 nM
Compound 3: middle estimate off by 1.3-fold (0.12 log units), on the high side; the measured number falls inside the stated range.
By their numbers in this assay, from the lowest: compounds 1 and 3 (each within the scatter of the next); then compound 2.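

Within the data shown here, the first single-place comparison concerns the aromatic carbon between two ring nitrogen atoms: in this assay, replacing 5-ethylfuran-2-yl with 4-methyl-1,3-thiazol-2-yl gives a 1.6-fold higher number from compound 1 to compound 3 (0.20 log units; within the scatter). At this position, then, one five-membered aromatic ring with 1 hetero atom can be exchanged for one with 2 hetero atoms, with a different substituent on the ring, and the two compounds cannot be told apart in this measurement. No supporting evidence is available to explain this result.

Among these compounds, the single exchange changes the ring and its alkyl substituent together, so it cannot show what each contributes, and it leaves open whether the position would accommodate something further removed from these two groups, such as a dimethylamino group, a carboxylic acid or a longer alkyl chain. Compound 2 still differs from compound 1 in more than one place, so the separate contributions of those differences also remain unresolved.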